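Lactam Ring Changes and Rat Microsomal Clearance

The source may report more compounds than this note shows. Statements on the series, on what has been measured and on what is new or still open speak of the compounds shown alone.

Measured compounds:
compound 1, `CC(C)c1noc(N2CCC(Oc3cc(N4CCc5cc(N6CC(O)CCC6=O)ccc54)ncn3)CC2)n1`: 7 mL.min-1.g-1
compound 2, `CC(C)c1noc(N2CCC(Oc3cc(N4CCc5cc(N6CCOCC6=O)ccc54)ncn3)CC2)n1`: 46 mL.min-1.g-1

In an ADME assay on microsomes from liver (Rattus norvegicus) for metabolic stability, read by LC-MS, using NADPH, with a stated time of 30 min, tested at 1 uM (a higher number here means faster removal of the compound, a lower number slower removal), compound 1 gives 7 mL.min-1.g-1 and compound 2 gives 46 mL.min-1.g-1. Among the measured compounds shown here, compound 2 stands highest of the two measured numbers, and the one measured step, a 6.6-fold higher number from compound 1 to compound 2 (0.82 log units; beyond the scatter), separates it from compound 1. Compound 3 `CC(C)c1noc(N2CCC(Oc3cc(N4CCc5cc(N6CCCC6=O)ccc54)ncn3)CC2)n1` differs from compound 2 by 2-oxopyrrolidin-1-yl in place of 3-oxomorpholin-4-yl on an aromatic carbon. For the measured compounds named here, no measured step involves the 2-oxopyrrolidin-1-yl group; the only step available, from compound 1 to compound 2, concerns a different pair of groups and so offers little direct guidance for this change. With nothing closer to lean on, the number for compound 3 is taken to lie near that of compound 2. Compound 3 is thus expected to show a step of a 1.1-fold higher number from compound 2 to compound 3 (0.04 log units; within the scatter) that remains within the scatter. Compound 3 is estimated at 50 mL.min-1.g-1, within a range from 20 mL.min-1.g-1 to 125 mL.min-1.g-1.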

Compound 3, intrinsic clearance in microsomes: 138 mL.min-1.g-1
Beside the measured number, compound 3's estimate is 2.8-fold (0.44 log units) below it; the measured number lies above the stated range.
By their numbers in this assay, from the lowest: compound 1; then compound 2; then compound 3.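

In this assay, 2-oxopyrrolidin-1-yl in place of 3-oxomorpholin-4-yl brings a 3.0-fold higher number from compound 2 to compound 3 (0.48 log units; beyond the scatter) and so shows that the number at this aromatic carbon still moves between two groups with 0 hydrogen-bond donors, something the earlier step, in which 5-hydroxy-2-oxopiperidin-1-yl left, could not show. Against that hydroxylated group, the same 2-oxopyrrolidin-1-yl gives a 20-fold higher number from compound 1 to compound 3 (1.29 log units; beyond the scatter) and widens the spread at this one position from modest to large. No evidence is available that explains either step.

The change from 3-oxomorpholin-4-yl alters ring size and hetero atom count together, so the compounds shown do not separate the two. Also open, going by these compounds, is how an unsubstituted 2-oxopiperidin-1-yl group, or a 2-oxopyrrolidin-1-yl ring carrying a hydroxyl group, would compare at this position.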